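Ethylcarbamoyl in place of acetyl on the side chain

The compounds below may be only part of what the source reports. "The series", "measured", "known", "first", "only" and "open" are said of these compounds alone.

Among the compounds with values here, compound 1 `COc1nc(C)c(Nc2nc(Cl)cn([C@H](COC(C)=O)C3CC3)c2=O)cc1C` gives 5.3 nM in an assay on frontal cortex for displacement of a labelled ligand from corticotropin-releasing factor receptor 1 (Rattus norvegicus), with a stated time of 2 h (a higher number here means a weaker inhibitor, a lower number a stronger inhibitor), the lowest of the three numbers known so far. Compound 3 `COc1ccc(NC(=O)OC[C@H](C2CC2)n2cc(Cl)nc(Nc3cc(C)c(OC)nc3C)c2=O)c(C)n1` gives 9.2 nM, and compound 2 `COc1nc(C)c(Nc2nc(Cl)cn([C@H](COC(=O)c3ccccn3)C3CC3)c2=O)cc1C` gives 67 nM. The steps from compound 1 read: a 13-fold higher number from compound 1 to compound 2 (1.10 log units; beyond the scatter); a 1.7-fold higher number from compound 1 to compound 3 (0.24 log units; within the scatter); and between the two larger groups, a 7.3-fold lower number from compound 2 to compound 3 (0.86 log units; beyond the scatter).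

Compound 4 `CCNC(=O)OC[C@H](C1CC1)n1cc(Cl)nc(Nc2cc(C)c(OC)nc2C)c1=O` is not yet measured. It differs from compound 1 at one place: ethylamino in place of methyl on a carbonyl carbon

Within the data shown here, two measured steps bear on this. The step to compound 3, which also replaces the methyl on the carbonyl carbon by an amino group, stays within the scatter a 1.7-fold higher number from compound 1 to compound 3 (0.24 log units; within the scatter). The step to compound 2, a pyridin-2-yl at the same place, is the one large loss a 13-fold higher number from compound 1 to compound 2 (1.10 log units; beyond the scatter). The ethylamino group is closer in kind to the change that cost nothing, so no step beyond the scatter is expected for compound 4 in this assay, with a slight lean toward a higher number because of a 1.7-fold higher number from compound 1 to compound 3 (0.24 log units; within the scatter).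

Compound 4 is therefore estimated at 8 nM, within 3 nM to 25 nM. The expected step is a 1.5-fold higher number from compound 1 to compound 4 (0.18 log units; within the scatter).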

Compound 4, half-maximal inhibitory concentration: 14 nM
Compound 4: the middle estimate sits 1.8-fold (0.24 log units) below what was measured; the range from low to high includes it.
By their numbers in this assay, from the lowest: compounds 1, 3 and 4 (each within the scatter of the next, the first and the last beyond it); then compound 2.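

In this assay, ethylcarbamoyl in place of acetyl is not a free change: a 2.6-fold higher number from compound 1 to compound 4 (0.42 log units; beyond the scatter), a modest loss, whereas the aryl carbamate of compound 3 stayed within the scatter of compound 1. The group on the amide-type nitrogen can nonetheless shrink from 6-methoxy-2-methylpyridin-3-yl to ethyl with no readable change, a 1.5-fold higher number from compound 3 to compound 4 (0.18 log units; within the scatter), so these two carbamates cannot be told apart here. Ethylamino also stands clear of the pyridin-2-yl ester, a 4.8-fold lower number from compound 2 to compound 4 (0.68 log units; beyond the scatter), which extends to a small alkyl carbamate the separation already seen for compound 3; no data bear on the origin of these steps.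

Going by these compounds, whether the amide hydrogen matters remains open, and a dimethylamino group on the carbonyl carbon would test it. On these data alone, how a longer chain such as butylamino, or a cyclopropylamino group, would compare with ethylamino also remains open.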